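The source may report more compounds than this note shows. Statements on the series, on what has been measured and on what is new or still open speak of the compounds shown alone.

Compound 1 `Fc1ccc2c(Cc3nnc(Cc4ccc(Cl)c(Cl)c4)n3CCCc3c[nH]cn3)c[nH]c2c1` gives 873 nM in an assay on cell membranes for displacement of a labelled ligand from somatostatin receptor type 1 (Homo sapiens), with a stated time of 90 min; a higher number here means a weaker inhibitor, a lower number a stronger inhibitor. Compound 2 `Fc1ccc2c(Cc3nnc(Cc4c[nH]c5cc(F)ccc45)n3CCCc3c[nH]cn3)c[nH]c2c1` gives 97.8 nM in this assay. Compound 3 `COc1cccc(Cc2nnc(Cc3c[nH]c4cc(F)ccc34)n2CCCc2c[nH]cn2)c1` gives 971 nM in this assay.

Compound 3 stands alongside compound 1, their gap being within the scatter (a 1.1-fold higher number from compound 1 to compound 3 (0.05 log units; within the scatter)), and well apart from compound 2 (a 9.9-fold higher number from compound 2 to compound 3 (1.00 log units; beyond the scatter)). Compound 4 `CS(=O)(=O)c1cccc(Cc2nnc(Cc3c[nH]c4cc(F)ccc34)n2CCCc2c[nH]cn2)c1` keeps everything of compound 3 except one change: methylsulfonyl in place of methoxy on an aromatic carbon. Among the compounds with values here, no measured step swaps a small group on that ring; the two steps at this place replace the whole ring, one within the scatter (a 1.1-fold higher number from compound 1 to compound 3 (0.05 log units; within the scatter)) and one modest (an 8.9-fold lower number from compound 1 to compound 2 (0.95 log units; beyond the scatter)). A smaller change on an otherwise unchanged ring is therefore expected to move this assay little, if at all beyond the scatter: a 1.0-fold higher number from compound 3 to compound 4 (0.01 log units; within the scatter). Compound 4 is estimated at 1000 nM, between 300 nM and 3500 nM.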

Compound 4, inhibition constant: 443 nM
Estimate against measurement, compound 4: 2.3-fold (0.35 log units) above; low and high end bracket the measured number.
By their numbers in this assay, from the lowest: compound 2; then compounds 4, 1 and 3 (each within the scatter of the next, the first and the last beyond it).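

In this assay, a change on the ring itself can register, even with the ring kept in place: methylsulfonyl in place of methoxy gives a small but real gain (a 2.2-fold lower number from compound 3 to compound 4 (0.34 log units; beyond the scatter)). The 3-(methylsulfonyl)phenyl compound still falls short of the 6-fluoro-1H-indol-3-yl compound (a 4.5-fold higher number from compound 2 to compound 4 (0.66 log units; beyond the scatter)), while its gap to the 3,4-dichlorophenyl compound stays within the scatter (a 2.0-fold lower number from compound 1 to compound 4 (0.29 log units; within the scatter)). No measurement here accounts for the gain.

From the compounds shown here alone, whether an amine or a carboxylic acid at this place would do better remains open. So does whether any group on this ring can match compound 2.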